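This account rests on a few compounds, and the source may have more. Where it says the series, first, only, none or still open, it means among the compounds named here.

Measured so far:
compound 1 `C#Cc1nc(C(=O)OCC)cs1`: 2670 nM
compound 2 `C=Cc1nc(C(=O)OCC)cs1`: > 40000 nM

For the measured compounds named here, compound 1 holds the only number so far in a functional assay on NCI-H522 cells (Homo sapiens) for cytotoxicity, with a stated time of 3 days; on this read-out higher numbers stand for weaker inhibition and lower numbers for stronger inhibition; the other value shown there is a limit, not a number. For compound 2 the value is the limit of > 40000 nM in this assay, at which 1 of the 2 values shown sits. Going by the values given here, the one measured step, an at least 14-fold higher number from compound 1 to compound 2 (1.17 log units; beyond the scatter), shows that the ethynyl group on the shared core carries much of the activity on this read-out. Compound 3 `CCOC(=O)c1csc(C#Cc2ccccc2)n1` keeps that ethynyl and differs from compound 1 by phenyl in place of hydrogen on a triple-bonded carbon. Among the compounds with values here, no measured step touches the triple-bonded carbon itself, so the measured step gives no direct guide to the size or direction of this change. Compound 3 is therefore expected to differ little from its parent, with wide uncertainty, as a 1.8-fold lower number from compound 1 to compound 3 (0.25 log units; within the scatter). The estimate for compound 3 in this assay is 1500 nM, expected to lie between 200 nM and 10000 nM.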

Compound 3, half-maximal inhibitory concentration: > 40000 nM
Compound 3 gave a limit, no number; the forecaster's own chance of this, stated with the estimate: 15%; at least 26-fold (1.42 log units) between middle value and limit.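

Keeping the triple bond is not enough for activity in this assay: with phenyl in place of hydrogen on the triple-bonded carbon, the read-out shows an at least 14-fold higher number from compound 1 to compound 3 (1.17 log units; beyond the scatter). The value of compound 3, > 40000 nM, is a limit of the assay and not a number, so the full size of this change cannot be read. Both changes at the ethynyl group of compound 1 have now ended at the same point: the limit of > 40000 nM in this assay, at which 2 of the 3 values shown sit.

Among the compounds shown, only hydrogen and phenyl stand on the triple-bonded carbon. As far as these compounds go, how a methyl group or an aminomethyl group there would read in this assay stays open, as does the effect of a carboxylic acid in place of the ethyl ester.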